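The compounds below may be only part of what the source reports. "The series", "measured", "known", "first", "only" and "open" are said of these compounds alone.

Within the data shown here, in a functional assay on MGC-803 cells (Homo sapiens) for inhibition, read by sulforhodamine B assay (a lower number here means a stronger inhibitor, a higher number a weaker inhibitor), compound 3 `Cc1ccc(NC2=CC(=O)c3c(nc4n3[C@H]3OC[C@@H](O)[C@H]3OC4)C2=O)cc1C` gives 1050 nM, standing second highest of the three numbers known; its nearest neighbour is compound 1 `Cc1ccc(NC2=CC(=O)c3nc4n(c3C2=O)[C@H]2OC[C@@H](O)[C@H]2OC4)cc1C`, which in this assay gives 860 nM, and its furthest is compound 2 `CCCc1ccc(NC2=CC(=O)c3c(nc4n3[C@H]3OC[C@@H](O)[C@H]3OC4)C2=O)cc1`, which gives 1920 nM. Among the measured compounds shown here, the one measured step, a 1.8-fold lower number from compound 2 to compound 3 (0.26 log units; within the scatter), swaps one aryl group for another on the amine nitrogen and stays within the scatter. For the measured compounds named here, compound 4 `O=C1C(N2CCCCC2)=CC(=O)c2c1nc1n2[C@H]2OC[C@@H](O)[C@H]2OC1` carries a different kind of change, (piperidin-1-yl in place of (3,4-dimethylphenyl)amino on a double-bonded ring carbon), for which no measured step exists; the aryl-to-aryl step of compound 2 to compound 3 offers only weak guidance. Compound 4 is therefore expected to give 2200 nM in this assay, within 500 nM to 9000 nM, the estimated step being a 2.1-fold higher number from compound 3 to compound 4 (0.32 log units; beyond the scatter).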

Compound 4, half-maximal inhibitory concentration: > 4000 nM
Compound 4: no number, only a limit; the forecaster's own chance of this, stated with the estimate: 10%; middle value at least 1.8-fold (0.25 log units) away from the limit.
By their numbers in this assay, from the lowest: compounds 1, 3 and 2 (each within the scatter of the next, the first and the last beyond it). At a limit, above all of these: compound 4.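

In this assay, piperidin-1-yl in place of (3,4-dimethylphenyl)amino on the double-bonded ring carbon gives an at least 3.8-fold higher number from compound 3 to compound 4 (0.58 log units; beyond the scatter), while the aryl exchange on the amine nitrogen, a 1.8-fold lower number from compound 2 to compound 3 (0.26 log units; within the scatter), stays within the scatter. This position therefore tolerates one aryl amine for another, but the number rises once the aryl amine is replaced by piperidin-1-yl. Compound 4 stands at a limit of the assay, not at a number: the limit of > 4000 nM in this assay, at which 1 of the 4 values shown sits.

Both the aromatic ring and the hydrogen-bond donor leave in this one change, so the compounds shown cannot separate the two. A cyclohexylamino group, which would keep the amine hydrogen without the aromatic ring, remains an open case.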